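Hydroxy in place of methoxy on a shared pyrazole-free core

This account rests on a few compounds, and the source may have more. Where it says the series, first, only, none or still open, it means among the compounds named here.

Of the compounds shown here, three sharing one core have been measured in a functional assay on BT-549 cells (Homo sapiens) for inhibition, read by sulforhodamine B assay, with a stated time of 48 h; on this read-out higher numbers stand for weaker inhibition of growth and lower numbers for stronger inhibition of growth. Compound 1 `O=C(Nc1cccc(-n2cc(-c3ccncc3)c(-c3ccc(Cl)c(O)c3)n2)c1)Nc1cccc(C(F)(F)F)c1` gives 21400 nM. Compound 2 `COc1cc(-c2nn(-c3cccc(NC(=O)c4cccc(C(F)(F)F)c4)c3)cc2-c2ccncc2)ccc1Cl` gives 46800 nM. Compound 3 `COc1cc(-c2nn(-c3cccc(NC(=O)Nc4ccc(Cl)c(Cl)c4)c3)cc2-c2ccncc2)ccc1Cl` gives 27600 nM, the second highest of the three numbers, though its gap to each of the others lies within the scatter. Among the measured compounds shown here, the one measured step between neighbours, a 1.7-fold lower number from compound 2 to compound 3 (0.23 log units; within the scatter), exchanges the group on the carbonyl and changes little.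

Compound 4 `O=C(Nc1cccc(-n2cc(-c3ccncc3)c(-c3ccc(Cl)c(O)c3)n2)c1)Nc1ccc(Cl)c(Cl)c1` is compound 3 with one alteration: hydrogen in place of methyl on an oxygen on an aromatic ring. For the measured compounds named here, no measured pair isolates this change; compound 1 and compound 3 differ in this oxygen substituent but also in the group on the carbonyl, so compound 1 with 21400 nM and compound 3 with 27600 nM show only that the two together leave the number within the scatter. With nothing in the measured steps pointing to a shift, the step from compound 3 to compound 4 is estimated as a 1.1-fold lower number from compound 3 to compound 4 (0.04 log units; within the scatter), no change beyond the scatter. Compound 4 is therefore expected to give about 25000 nM, within a range of 10000 nM to 60000 nM.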

Compound 4, concentration for total growth inhibition: 16100 nM
For compound 4 the middle estimate is 1.6-fold (0.19 log units) above the measured one; the range from low to high includes it.
By their numbers in this assay, from the lowest: compounds 4, 1, 3 and 2 (each within the scatter of the next, the first and the last beyond it).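

In this assay, among the compounds shown here, the step of a 1.7-fold lower number from compound 3 to compound 4 (0.23 log units; within the scatter) is the first to isolate methoxy to hydroxy on the aromatic ring, and it lies within the scatter, so this single change cannot be told apart from repeat-measurement noise. With the hydroxy group held constant, the step of a 1.3-fold lower number from compound 1 to compound 4 (0.12 log units; within the scatter) also lies within the scatter, so the exchange of 3-(trifluoromethyl)phenyl for 3,4-dichlorophenyl on the amide-type nitrogen likewise shows no clear effect. No supporting measurement is available to explain these results.

The compounds shown leave open whether a longer chain on this oxygen, such as ethoxy or butoxy, would give a number clearly apart from these. They also leave open what an amine or a carboxylic acid in place of the hydroxy group would do on this read-out.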